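This account rests on a few compounds, and the source may have more. Where it says the series, first, only, none or still open, it means among the compounds named here.

In a functional assay on Caco-2 cells (Homo sapiens) for inhibition, read by sulforhodamine B assay, with a stated time of 48 h (on this read-out higher numbers stand for weaker inhibition and lower numbers for stronger inhibition), two compounds built on one shared core have been tested. Compound 1 `COC(=O)[C@@]1(C)C[C@@H](c2coc3ccc(Br)cc3c2=O)N(c2ccccc2)O1` carries a bromo group, and its > 60000 nM is a limit of the assay and not a number. Going by the values given here, compound 2 `COC(=O)[C@@]1(C)C[C@@H](c2coc3ccc(F)cc3c2=O)N(c2ccccc2)O1` carries a fluoro group on the same aromatic carbon and gives 29500 nM, the only true number so far. Compound 3 `COC(=O)[C@@]1(C)C[C@@H](c2coc3ccc(C)cc3c2=O)N(c2ccccc2)O1` is yet to be measured and differs from compound 2 as follows: methyl in place of fluoro on an aromatic carbon. Among the compounds with values here, the one measured step at this carbon is an at least 2.0-fold lower number from compound 1 to compound 2 (0.30 log units; that floor lies within the scatter), and its floor lies within the scatter. That step fixes no firm size, so no step beyond the scatter is expected in this assay. The expected step is a 1.1-fold higher number from compound 2 to compound 3 (0.04 log units; within the scatter). The estimate for compound 3 is 32000 nM, with an expected range from 14000 nM to 60000 nM.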

Compound 3, half-maximal inhibitory concentration: 19700 nM
Compound 3: the middle estimate sits 1.6-fold (0.21 log units) above what was measured; measured number inside the range.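

In this assay, methyl in place of fluoro on this aromatic carbon gives a 1.5-fold lower number from compound 2 to compound 3 (0.18 log units; within the scatter), so the data cannot separate these two groups. Methyl in place of bromo gives an at least 3.0-fold lower number from compound 1 to compound 3 (0.48 log units; beyond the scatter), which makes it the first step at this carbon to lie beyond the scatter and shows that the choice of group here can change the read-out. That size is only a floor, because compound 1 stands at a limit of the assay and not at a true number: the limit of > 60000 nM in this assay, at which 1 of the 3 values shown sits.

Still open, as far as these compounds go, is how an amine, a carboxylic acid or a longer chain such as propyl would behave on this carbon. Also open, from the compounds shown here alone, is whether any group here could bring the number far under those of compound 2 and compound 3.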